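A fluoro step from compound 2

The source may hold more compounds than are shown below. What is called first, only, known or untested is meant among the compounds shown, and "the series" means these compounds.

Compound 1 `CN[C@@H](C)c1ccc(N2CC[C@H](NS(=O)(=O)c3ccc4cc(Cl)ccc4c3)C2=O)c(F)c1`: > 10% (a limit)
Compound 2 `O=C1[C@@H](NS(=O)(=O)c2ccc3cc(Cl)ccc3c2)CCN1c1ccc2c(c1)CCNC2`: 24%

Within the data shown here, in an in vivo ADME assay on the whole organism (strain Sprague-Dawley) for pharmacokinetics, with Rattus norvegicus as the target (on this read-out lower numbers stand for lower oral bioavailability and higher numbers for higher oral bioavailability), compound 2 gives 24%, the only exact number so far. The reading for compound 1 is a limit, not a number. Compound 3 `O=C1[C@@H](NS(=O)(=O)c2ccc3cc(Cl)ccc3c2)CCN1c1cc2c(cc1F)CNCC2` differs from compound 2 in one place: fluoro in place of hydrogen on an aromatic carbon. Among the measured compounds shown here, no measured pair shows the size of such a step, so the expectation stays close to compound 2 at 24%. The expected step, a number 2 percentage points higher from compound 2 to compound 3 (within the scatter), lies within the usual scatter, with no firm direction. For compound 3, the expected value is 26%, with an estimated range of 10% to 45%.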

Compound 3, oral bioavailability: 28%
Estimate against measurement, compound 3: 2 percentage points below, and the stated range covers the measured number.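

In this assay, among these compounds, this change now has a measured size, a number 4 percentage points higher from compound 2 to compound 3 (within the scatter), which no earlier pair could give. Fluoro in place of hydrogen on this aromatic carbon, ortho to a large group, thus keeps the read-out within the scatter of the hydrogen compound. Compound 1 offers no further comparison, as it carries a limit and not a number: the limit of > 10% in this assay, at which 1 of the 3 values shown sits.

Going by these compounds, it remains open whether chloro, methoxy or a nitrile on this same carbon would stay within the scatter too. Fluoro on the other aromatic carbons of this ring also remains open.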